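A few compounds are considered here, and "the series" means these few. Any claim that something is new, unique, unknown or untested is made for them only; others in the source may bear on it.

The study centres on two piperidine-linked sulfonamides that share a core and differ only in the group attached to the sulfonyl sulfur. Compound 1 `CC1CCN(C2CCN(S(=O)(=O)c3ccc(F)cc3F)CC2)CC1` carries a 2,4-difluorophenyl there, and compound 2 `CC1CCN(C2CCN(S(=O)(=O)c3cccc4cnccc34)CC2)CC1` an isoquinoline. In a functional assay on DLD-1 cells (Homo sapiens) for antiproliferative activity, read by CellTiter-Glo, with a stated time of 72 h (a higher number here means a weaker inhibitor, a lower number a stronger inhibitor), compound 1 gives 102 nM, while compound 2 gives 225 nM. Of the two numbers available, compound 1 has the lower one, and the gap to compound 2 lies beyond the usual scatter, so compound 1 stands as the stronger inhibitor of the pair in this assay.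

The next compound, compound 3 `CC1CCN(C2CCN(S(=O)(=O)c3nccn3C)CC2)CC1`, keeps the same core and changes only the sulfonyl substituent: 1-methyl-1H-imidazol-2-yl in place of 2,4-difluorophenyl on a sulfonyl sulfur. Within the data shown here, no step between measured compounds involves this kind of change, so there is no direct precedent for it. A moderate step toward a higher number, of a size likely just beyond the scatter, is expected for a 2.5-fold higher number from compound 1 to compound 3 (0.39 log units; beyond the scatter). On that basis compound 3 is estimated to give 250 nM, with a plausible range from 80 nM to 800 nM, in this assay.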

Compound 3, half-maximal inhibitory concentration: > 5000 nM
Compound 3 gave a limit, no number; the forecaster's own chance of this, stated with the estimate: 5%; middle value at least 20-fold (1.30 log units) away from the limit.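

Until now, the sulfonyl substituent had been seen only as two different aromatic groups that stayed fairly close, with compound 1 at 102 nM and compound 2 at 225 nM in this assay, so the position had not yet shown how much could be lost there. Replacing 2,4-difluorophenyl with 1-methyl-1H-imidazol-2-yl on the sulfonyl sulfur gives an at least 49-fold higher number from compound 1 to compound 3 (1.69 log units; beyond the scatter), which shows that activity in this series depends strongly on the group at this place and that not every aromatic ring is accepted there. The reading for compound 3 is a limit and not a number, so this step has no upper end: the limit of > 5000 nM in this assay, at which 1 of the 3 values shown sits.

The compounds shown leave open which part of the change matters, as the five-membered ring, its two ring nitrogens and the methyl group all enter together, while the fluorines leave in the same step. They also do not show how a plain phenyl, a thiophene ring or a pyridine ring would read on the same sulfonyl sulfur, or whether an imidazole ring without the methyl group would behave as compound 3 does.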